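This account rests on a few compounds, and the source may have more. Where it says the series, first, only, none or still open, it means among the compounds named here.

Working notes on the urea series in a functional assay on CRL2813 cells (Homo sapiens) for antiproliferative activity, read by sulforhodamine B assay, with a stated time of 5 days; on this read-out higher numbers stand for weaker inhibition and lower numbers for stronger inhibition. Compound 1 `COc1cc(NC(=O)Nc2cc(C(F)(F)F)cc(C(F)(F)F)c2)ccc1C` gives 500 nM. Compound 2 `COc1cc(NC(=O)Nc2ccc(Cl)c(Cl)c2)ccc1C` gives 500 nM. Compound 3 `Cc1ccc(NC(=O)Nc2ccc(Cl)c(Cl)c2)cc1O` gives 2300 nM. Compound 2 and compound 3 differ in one place only, (hydrogen in place of methyl on an oxygen on an aromatic ring), and that change produces a 4.6-fold higher number from compound 2 to compound 3 (0.66 log units; beyond the scatter). Compound 1 and compound 2 carry different aryl groups on the far side of the urea; the difference between the two cores is not broken down here, and their two numbers stand level at the digits read, within the scatter, so no order is put between them.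

Compound 4 `Cc1ccc(NC(=O)Nc2cc(C(F)(F)F)cc(C(F)(F)F)c2)cc1O` has not yet been measured. Against compound 1 it shows (hydrogen in place of methyl on an oxygen on an aromatic ring). The place of the change reads the same, word for word, as for the step from compound 2 to compound 3, so this is the same change, made on a different core; among the compounds here it occurs two times in all, once measured and once not. Only a single measured instance is available, and whether the effect carries over between the two cores is not shown by anything else in the series. Within the data shown here, the step expected here is a 4.6-fold higher number from compound 1 to compound 4 (0.66 log units; beyond the scatter), set beside a 4.6-fold higher number from compound 2 to compound 3 (0.66 log units; beyond the scatter) as its only precedent. Compound 4 is therefore expected to come in around 2300 nM, with an estimated range of 900 nM to 6000 nM.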

Compound 4, half-maximal inhibitory concentration: 1200 nM
Compound 4: middle estimate off by 1.9-fold (0.28 log units), on the high side; low and high end bracket the measured number.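

In this assay the change from methoxy to hydroxy on the core of compound 1 gives a 2.4-fold higher number from compound 1 to compound 4 (0.38 log units; beyond the scatter), the same direction as on the core of compound 3, so the hydroxy compound carries the higher number in both pairs. The size of the step also carries over as far as two instances can tell, since the two steps cannot be told apart: the same change on two cores in this assay, a 4.6-fold higher number (0.66 log units; beyond the scatter) from compound 2 to compound 3 and a 2.4-fold higher number (0.38 log units; beyond the scatter) from compound 1 to compound 4, 1.9-fold (0.28 log units) apart, within the scatter of two such steps

This is one pair on each of two cores, which differ in the aryl group on the far side of the urea, so it supports carrying the change between these two cores only and gives no rule for other aryl groups, nor any reason why the change acts as it does.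

The compounds shown hold only methoxy or hydroxy at this oxygen and only two aryl groups on the far side of the urea, so it stays open how a longer chain such as ethoxy, or an amine in place of the methoxy, would read. Also open, going by these compounds, is whether the step would hold on a core whose far-side aryl group carries neither chlorine nor trifluoromethyl.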